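This account rests on a few compounds, and the source may have more. Where it says the series, first, only, none or still open, it means among the compounds named here.

Measured compounds:
compound 1 `COc1ccccc1/C=N/Nc1nc2ccccc2nc1Cc1ccccc1`, 790000 nM
compound 2 `COc1ccc(/C(C)=N/Nc2nc3ccccc3nc2Cc2ccccc2)cc1`, 280000 nM
compound 3 `C/C(=N\Nc1nc2ccccc2nc1Cc1ccccc1)c1ccc(O)cc1`, 8400000 nM

In an assay on isolated protein for inhibition of Amine oxidase [flavin-containing] B (Homo sapiens), read by spectrophotometry (on this read-out higher numbers stand for weaker inhibition and lower numbers for stronger inhibition), compound 1 stands second highest of the three numbers, with compound 2 the nearest and compound 3 the furthest. Compound 4 `O=[N+]([O-])c1ccc(/C=N/Nc2nc3ccccc3nc2Cc2ccccc2)cc1` differs from compound 1 by 4-nitrophenyl in place of 2-methoxyphenyl on a carbon with a double bond to nitrogen. No measured step covers this change: the only step shown, a 30-fold higher number from compound 2 to compound 3 (1.48 log units; beyond the scatter), concerns a methyl replaced by hydrogen on an oxygen, and the gap between compound 1 and compound 2 combines two changes. Both comparisons show that alterations on this aryl group can move the number strongly in either direction. Without a direct precedent, compound 4 is expected to lie near compound 1, with a step of a 1.6-fold lower number from compound 1 to compound 4 (0.20 log units; within the scatter) judged plausible. The estimate for compound 4 is 500000 nM, within a range of 100000 nM to 2500000 nM.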

Compound 4, half-maximal inhibitory concentration: 960000 nM
Compound 4: the middle estimate sits 1.9-fold (0.28 log units) below what was measured; the measured number falls inside the stated range.
By their numbers in this assay, from the lowest: compound 2; then compounds 1 and 4 (each within the scatter of the next); then compound 3.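

In this assay, 4-nitrophenyl in place of 2-methoxyphenyl on a carbon with a double bond to nitrogen gives a 1.2-fold higher number from compound 1 to compound 4 (0.08 log units; within the scatter) and stays within the scatter. For the compounds shown here, this is the first direct comparison at this position, and it shows that one aryl group can replace the other without a readable change in the number. No evidence bears on why the two compounds read alike. Still open, from the compounds shown here alone, is whether an amine or a carboxylic acid on this aryl ring would also leave the number unchanged.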